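Pentafluorosulfanyl anilides: a trifluoromethyl step carried over

This account rests on a few compounds, and the source may have more. Where it says the series, first, only, none or still open, it means among the compounds named here.

Of the compounds shown here, three with a pentafluorosulfanyl-bearing anilide have been measured in a functional assay on LNCaP cells (Homo sapiens) for antiproliferative activity, read by propidium iodide staining, with a stated time of 96 h; on this read-out higher numbers stand for weaker inhibition and lower numbers for stronger inhibition. Compound 1 `CC(O)(CSc1ccc(F)cc1)C(=O)Nc1ccc(S(F)(F)(F)(F)F)cc1` gives 12500 nM. Compound 2 `CC(O)(CSc1ccc(C(F)(F)F)cc1)C(=O)Nc1ccc(S(F)(F)(F)(F)F)cc1` gives 17000 nM; it differs from compound 1 by trifluoromethyl in place of fluoro on an aromatic carbon, and that change made a 1.4-fold higher number from compound 1 to compound 2 (0.13 log units; within the scatter). Compound 3 `CC(O)(CSc1ccc(F)cc1)C(=O)Nc1cccc(S(F)(F)(F)(F)F)c1` gives 26900 nM; how its core differs from that of compound 1 is not broken down here.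

Compound 4 `CC(O)(CSc1ccc(C(F)(F)F)cc1)C(=O)Nc1cccc(S(F)(F)(F)(F)F)c1` is not yet measured in this assay. It differs from compound 3 by trifluoromethyl in place of fluoro on an aromatic carbon, the same change as that from compound 1 to compound 2. Because the earlier change gave a 1.4-fold higher number from compound 1 to compound 2 (0.13 log units; within the scatter), the step for compound 4 is expected to be a 1.4-fold higher number from compound 3 to compound 4 (0.14 log units; within the scatter). Compound 4 is therefore estimated at 37000 nM, with a range from 20000 nM to 70000 nM.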

Compound 4, half-maximal inhibitory concentration: 17500 nM
The estimate for compound 4 lay 2.1-fold (0.33 log units) above the measured number, and the stated range ends above it.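

In this assay, the change of fluoro to trifluoromethyl on the second core gives a 1.5-fold lower number from compound 3 to compound 4 (0.19 log units; within the scatter). Set beside the same change on the first core, this step does not separate from the earlier one: the same change on two cores in this assay, a 1.4-fold higher number (0.13 log units; within the scatter) from compound 1 to compound 2 and a 1.5-fold lower number (0.19 log units; within the scatter) from compound 3 to compound 4, 2.1-fold (0.32 log units) apart, within the scatter of two such steps Carrying the change between these two cores therefore shows no measurable dependence on the core, but it does not establish that the change behaves alike on both, since neither step can be told apart from the scatter and only two cores are compared.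

The compounds shown leave open how a nitrile or an amine would read in place of the fluoro or trifluoromethyl group. Also open, on these data alone, is what a sulfone in place of the chain's sulfur would do.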